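A few compounds are considered here, and "the series" means these few. Any claim that something is new, unique, unknown or untested is made for them only; others in the source may bear on it.

Of the compounds shown here, three have been tested in a toxicity assay on Vero C1008 cells (Chlorocebus sabaeus) for cytotoxicity, read by neutral red uptake, with a stated time of 5 days; on this read-out higher numbers stand for lower toxicity in this test and lower numbers for higher toxicity in this test. Compound 1 `CC(C)(C)c1ccc(N(C(=O)c2ccco2)C(C(=O)NC2CCCC2)c2cccnc2)cc1` gives 101000 nM, compound 2 `CC(C)(C)c1ccc(N(C(=O)c2ccco2)C(C(=O)NC2CCCCC2)c2cccnc2)cc1` gives 18200 nM, and compound 3 `C[C@H](NC(=O)C(c1cccnc1)N(C(=O)c1ccco1)c1ccc([Si](C)(C)C)cc1)c1ccccc1` gives 19400 nM, the second highest of the three numbers, close to compound 2 and well apart from compound 1. Compound 4 `C[C@H](NC(=O)C(c1cccnc1)N(C(=O)c1ccco1)c1ccc(-c2cccs2)cc1)c1ccccc1` differs from compound 3 in one place: a group of 5 heavy atoms (4 carbon, 1 sulfur; one five-membered aromatic ring with 1 hetero atom) in place of a group of 4 heavy atoms (3 carbon, 1 silicon; no ring), on an aromatic carbon. Within the data shown here, the only measured step, a 5.5-fold lower number from compound 1 to compound 2 (0.74 log units; beyond the scatter), concerns the ring on the amide-type nitrogen and not the aromatic carbon changed here, so it does not bear on this change. Among the measured compounds shown here, with no measured step touching that aromatic carbon, a step within the scatter is expected for compound 4, a 1.3-fold lower number from compound 3 to compound 4 (0.11 log units; within the scatter). Compound 4 is therefore estimated at 15000 nM in this assay, with a range from 5000 nM to 50000 nM.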

Compound 4, half-maximal cytotoxic concentration: 89600 nM
The estimate for compound 4 lay 6.0-fold (0.78 log units) below the measured number, outside the stated range (above it).
By their numbers in this assay, from the lowest: compounds 2 and 3 (each within the scatter of the next); then compounds 4 and 1 (each within the scatter of the next).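

Among these compounds, this is the first measured change at the aromatic carbon para to a large group, and it shows that this position matters in this assay: thiophen-2-yl in place of the silicon-bearing group gives a 4.6-fold higher number from compound 3 to compound 4 (0.66 log units; beyond the scatter), which means lower toxicity in this test. A ring at this carbon is therefore tolerated with less toxicity here than the group without a ring, at least in this one pair. Nothing measured here explains the shift.

From the compounds shown here alone, whether a phenyl ring or an amine at this carbon would move the number the same way remains open. So does whether thiophen-2-yl would have a similar effect on compound 2, with its cyclohexyl amide.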